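Bromo addition to the inactive propanoyl compound

The source may report more compounds than this note shows. Statements on the series, on what has been measured and on what is new or still open speak of the compounds shown alone.

Measured in a functional assay on HepG2 cells (Homo sapiens) for cytotoxicity, read by MTT assay, with a stated time of 48 h; a higher number here means a weaker inhibitor, a lower number a stronger inhibitor:
- compound 1 `CC1=NN(C(=O)CCl)C(c2cc(Br)ccc2O)C1`: 16300 nM
- compound 2 `CCC(=O)N1N=C(C)CC1c1cc(Br)ccc1O`: "not active" (no number reported)
- compound 3 `CC1=NN(C(=O)CCc2ccccc2)C(c2cc(Br)ccc2O)C1`: 17900 nM

In this assay, among the compounds with values here, compound 2 stands without a number, reported as "not active" (no number reported), so no step can be counted from it. The next compound to test is compound 4 `CCC(=O)N1N=C(C)CC1c1cc(Br)cc(Br)c1O`, which differs from compound 2 as follows: bromo in place of hydrogen on an aromatic carbon. The new bromo sits on an aromatic carbon, ortho to a hydroxy group.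

Within the data shown here, the only measured step, a 1.1-fold higher number from compound 1 to compound 3 (0.04 log units; within the scatter), lies on the saturated chain and not on the aromatic ring, so it bears only indirectly. Among the measured compounds shown here, no measured step shows what a bromo in place of hydrogen does here. Any number for compound 4 would be a move towards stronger inhibition from the reading of compound 2, of a size that cannot be counted. A reading near the range of compound 1 at 16300 nM or weaker is expected, and another result without a number remains quite possible. Compound 4 is estimated at 30000 nM, with an expected range of 10000 nM to 90000 nM.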

Compound 4, half-maximal inhibitory concentration: 41400 nM
Beside the measured number, compound 4's estimate is 1.4-fold (0.14 log units) below it; the range from low to high includes it.
By their numbers in this assay, from the lowest: compounds 1 and 3 (each within the scatter of the next); then compound 4.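

Within the data shown here, compound 2 stands at "not active" (no number reported) and compound 4 at 41400 nM in this assay with no step readable between them. Nothing measured bears on the cause of this result. The compounds shown leave open how large the change from the added bromo is, and whether it carries over to the chains of compound 1 and compound 3.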